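This account rests on a few compounds, and the source may have more. Where it says the series, first, only, none or still open, it means among the compounds named here.

Of the compounds shown here, three sharing one core have been tested in a functional assay on HL-60 cells (Homo sapiens) for antiproliferative activity, read by MTT assay, with a stated time of 72 h; on this read-out lower numbers stand for stronger inhibition and higher numbers for weaker inhibition: compound 1 `COc1cc(-n2ncnc2-c2ccc(Cl)cc2)cc(OC)c1OC`, compound 2 `COc1cccc(-c2ncnn2-c2cc(OC)c(OC)c(OC)c2)c1` and compound 3 `COc1cc(-n2ncnc2-c2ccccc2)cc(OC)c1OC`. Compound 1 gives > 10000 nM, which is a limit and not a number. Compound 2 gives > 10000 nM, again only a limit. Compound 3 gives > 10000 nM, also only a limit, so it has no readable position in the series. The set as a whole offers (the limit of > 10000 nM in this assay, at which 3 of the 3 values shown sit).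

Compound 4 `COc1cc(-n2ncnc2-c2ccc(SC)cc2)cc(OC)c1OC` carries methylsulfanyl in place of hydrogen on an aromatic carbon, para to a large group: methylsulfanyl in place of hydrogen on an aromatic carbon. Within the data shown here, two measured steps bear on this change: a step that the two limits leave unreadable from compound 1 to compound 3 and a step that the two limits leave unreadable from compound 2 to compound 3. Neither has a size that can be carried over. The chloro group of compound 1 still left it at > 10000 nM, so a single added group is not expected to bring much in this assay. The estimated step is an at least 1.2-fold lower number from compound 3 to compound 4 (0.09 log units; that floor lies within the scatter), towards stronger inhibition if it can be read at all. For compound 4 the expected value is 8000 nM, with an estimated range from 500 nM to 30000 nM.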

Compound 4, half-maximal inhibitory concentration: 500 nM
For compound 4 the middle estimate is 16-fold (1.20 log units) above the measured one; the range from low to high includes it.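

In this assay, this position, para to a large group, proves able to carry a large change: methylsulfanyl in place of hydrogen gives an at least 20-fold lower number from compound 3 to compound 4 (1.30 log units; beyond the scatter). The gain depends on which group sits there, as methylsulfanyl in place of chloro gives an at least 20-fold lower number from compound 1 to compound 4 (1.30 log units; beyond the scatter), and 4-(methylsulfanyl)phenyl in place of 3-methoxyphenyl gives an at least 20-fold lower number from compound 2 to compound 4 (1.30 log units; beyond the scatter). The steps among compound 1, compound 2 and compound 3 cannot be read, and the three new steps are floors only, with their true sizes hidden by a limit: the limit of > 10000 nM in this assay, at which 3 of the 4 values shown sit.

As far as these compounds go, it remains open whether the sulfur atom itself is needed, or whether a 4-methoxy or 4-methyl group in the same place would serve as well. Also open, from the compounds shown here alone, is how a longer chain on the sulfur, such as ethylsulfanyl, or a methylsulfonyl group would compare with compound 4.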